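The compounds below may be only part of what the source reports. "The series", "measured", "known", "first", "only" and "open" are said of these compounds alone.

Of the compounds shown here, three of one shared core have been measured in a functional assay for activation of Alpha-1A adrenergic receptor (Homo sapiens), read by calcium flux; on this read-out lower numbers stand for an effect already at smaller amounts and higher numbers for an effect only at larger amounts of compound. Compound 1 `c1csc(-c2ccccc2OCC2=NCCN2)c1` gives 1 nM. Compound 2 `c1ccc(-c2ccoc2)c(OCC2=NCCN2)c1` gives 0.501 nM, and the step of a 2.0-fold lower number from compound 1 to compound 2 (0.30 log units; within the scatter) is one the assay cannot tell apart from noise. Compound 3 `c1ccc(-c2cc[nH]n2)c(OCC2=NCCN2)c1` gives 5.01 nM, the highest number of the three: the steps of a 5.0-fold higher number from compound 1 to compound 3 (0.70 log units; beyond the scatter) and a 10-fold higher number from compound 2 to compound 3 (1.00 log units; beyond the scatter) both lie beyond the scatter, so compound 3 is read as the least potent of the measured set.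

Compound 4 `Cc1ccoc1-c1ccccc1OCC1=NCCN1` differs from compound 3 in one place: 3-methylfuran-2-yl in place of 1H-pyrazol-3-yl on an aromatic carbon. The ring that enters has one hetero atom and no hydrogen-bond donor, which brings compound 4 closer to compound 1 and compound 2 than to compound 3. Both steps that bear on this change point the same way: moving from a one-hetero-atom ring to the pyrazolyl ring raised the number, as seen in a 5.0-fold higher number from compound 1 to compound 3 (0.70 log units; beyond the scatter) and a 10-fold higher number from compound 2 to compound 3 (1.00 log units; beyond the scatter). The reverse move is therefore expected to lower the number. Among the compounds with values here, the added methyl group has no measured counterpart here, so the expected size carries extra uncertainty.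

For compound 4 the expected value in this assay is 1 nM, within a range of 0.3 nM to 4 nM. This estimate corresponds to an expected step of a 5.0-fold lower number from compound 3 to compound 4 (0.70 log units; beyond the scatter).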

Compound 4, half-maximal effective concentration: 3.16 nM
Compound 4: the middle estimate sits 3.2-fold (0.50 log units) below what was measured, and the stated range covers the measured number.
By their numbers in this assay, from the lowest: compounds 2 and 1 (each within the scatter of the next); then compounds 4 and 3 (each within the scatter of the next).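

In this assay, having a ring with one hetero atom and no hydrogen-bond donor does not by itself set the number at this place on the shared core: with a 1.6-fold lower number from compound 3 to compound 4 (0.20 log units; within the scatter), the 3-methylfuran-2-yl ring cannot be told apart from the 1H-pyrazol-3-yl ring. Nor do the rings with one hetero atom act as a single family, since a 6.3-fold higher number from compound 2 to compound 4 (0.80 log units; beyond the scatter) and a 3.2-fold higher number from compound 1 to compound 4 (0.50 log units; beyond the scatter) set compound 4 apart from the other two, making it the compound that goes against the trend compound 1, compound 2 and compound 3 had suggested. Nothing measured here offers an explanation for this result.

The compounds shown leave open whether the gap between compound 4 and compound 2 goes with the added methyl group or with the change from furan-3-yl to a furan-2-yl ring, a question that unsubstituted furan-2-yl and 3-methylfuran-3-yl rings could help separate. Also open, on these data alone, is how this place on the core responds to a plain phenyl ring, or to a five-membered ring bearing an ethyl group, a methoxy group or an amine.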